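Methylating the phenol of an anilide chromone

The compounds below may be only part of what the source reports. "The series", "measured", "known", "first", "only" and "open" are said of these compounds alone.

Compound 1, `COc1ccc2c(=O)c(/C=C/C(=O)Nc3ccccc3)coc2c1`: in a functional assay on HeLa cells (Homo sapiens) for inhibition, read by MTT assay, with a stated time of 48 h (on this read-out higher numbers stand for weaker inhibition and lower numbers for stronger inhibition), compound 1 gives > 100000 nM, which is a limit of the assay and not a number.
Compound 2, `Cc1ccccc1NC(=O)/C=C/c1coc2cc(O)ccc2c1=O`: in this assay compound 2 gives 8670 nM.

Among the two results shown, compound 2 has the only actual number; the other result is the limit noted for compound 1 (the limit of > 100000 nM in this assay, at which 1 of the 2 values shown sits). Compound 3, `COc1ccc2c(=O)c(/C=C/C(=O)Nc3ccccc3C)coc2c1`, has not been measured in this assay. It differs from compound 2 by methyl in place of hydrogen on an oxygen on an aromatic ring. Within the data shown here, no measured pair differs in this single place, so the size of the step is an open question. Compound 1, which also carries a methoxy group on its core, sits at the limit of this assay, and this weighs on the expectation. Compound 3 is therefore expected to be weaker than compound 2, with an estimated step of a 3.5-fold higher number from compound 2 to compound 3 (0.54 log units; beyond the scatter). The estimate for compound 3 in this assay is 30000 nM, expected to lie between 7000 nM and 120000 nM, with a fair chance that only a limit is reported.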

Compound 3, half-maximal inhibitory concentration: 7270 nM
Compound 3: middle estimate off by 4.1-fold (0.62 log units), on the high side; the range from low to high includes it.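

In this assay, the exchange of hydroxy for methoxy on the core gives a 1.2-fold lower number from compound 2 to compound 3 (0.08 log units; within the scatter), so on this oxygen on an aromatic ring, methyl in place of hydrogen makes no difference that can be read. With the methoxy group kept, methyl in place of hydrogen on an aromatic carbon gives an at least 13-fold lower number from compound 1 to compound 3 (1.13 log units; beyond the scatter), which places the large difference among these compounds at that carbon and not at the oxygen. That step starts from compound 1, whose value is a limit of the assay and not a number: the limit of > 100000 nM in this assay, at which 1 of the 3 values shown sits.

The compounds shown leave open whether the same exchange of hydroxy for methoxy would read alike without the methyl on the anilide ring. They also leave open how a longer chain on the oxygen, or an amine or a chlorine in place of that ring methyl, would read in this assay.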